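The source may report more compounds than this note shows. Statements on the series, on what has been measured and on what is new or still open speak of the compounds shown alone.

Working notes on the series.

Among the compounds with values here, in a functional assay on KOPN-8 cells (Homo sapiens) for antiproliferative activity, with a stated time of 72 h (a higher number here means that more compound is needed for the effect, a lower number that less compound is needed), compound 1 `COC(=O)c1cc(=O)c2c(OC)cc(OC)cc2n1S(=O)(=O)c1ccc(C)cc1` gives 6000 nM and is the only member of the set that yields a number. Compound 2 `COC(=O)c1cc(=O)c2cc(N)ccc2[nH]1` gives > 33700 nM, which is a limit of the assay and not a measured value, as the limit of > 33700 nM in this assay, at which 1 of the 3 values shown sits, shows. Compound 3 `COc1ccc(-c2cc(=O)c3c(OC)cc(OC)cc3n2S(=O)(=O)c2ccc(F)cc2)cc1` likewise gives > 65500 nM, again a limit rather than a number, as the limit of > 65500 nM in this assay, at which 1 of the 3 values shown sits, shows. Within the data shown here, compound 3 therefore stands at a limit in this assay, and of the three values shown one further value is also a limit; no step between two measured compounds that differ in one place is available, so no measured step size can be drawn on.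

Compound 4 `COc1ccc(-c2cc(=O)c3c(OC)cc(OC)cc3n2S(=O)(=O)c2ccc(Br)s2)cc1` differs from compound 3 in a single place: 5-bromothiophen-2-yl in place of 4-fluorophenyl on a sulfonyl sulfur. The sulfonyl on the aromatic nitrogen and the remainder of the shared core are kept.

With compound 3 sitting at a limit and nothing measured to set the size of such a change, the step from compound 3 to compound 4 is expected to be none beyond the usual scatter, the estimated step being a number no higher from compound 3 to compound 4 (the limit leaves the size open). Compound 4 is accordingly expected to give about 65500 nM in this assay, within a range of 15000 nM to 250000 nM, and most probably the result will again be reported only as a limit.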

Compound 4, half-maximal effective concentration: > 48200 nM
Compound 4: no number, only a limit; the forecaster's own chance of this, stated with the estimate: 70%; the middle value lies beyond the limit too.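

In this assay compound 3 and compound 4 both stand only at limits of the assay and not at numbers, so no step can be read between compound 3 and compound 4. The compounds shown leave open whether 5-bromothiophen-2-yl in place of 4-fluorophenyl on a sulfonyl sulfur has any effect in this assay.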